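This account rests on a few compounds, and the source may have more. Where it says the series, first, only, none or still open, it means among the compounds named here.

Measured compounds:
- compound 1, `S=C(NCc1ccccc1)N/N=C/c1ccc2ccccc2n1`: 62800 nM in a functional assay on HeLa cells (Homo sapiens) for antiproliferative activity, read by sulforhodamine B assay, with a stated time of 72 h; on this read-out lower numbers stand for stronger inhibition and higher numbers for weaker inhibition
- compound 2, `Cc1ccc(NC(=S)N/N=C/c2ccc3ccccc3n2)cc1`: 86000 nM

Compound 2 has the highest of the two numbers in this assay; its nearest neighbour is compound 1, and the step of a 1.4-fold higher number from compound 1 to compound 2 (0.14 log units; within the scatter) lies within the scatter, so the two values cannot be told apart. Compound 3, `Cc1ccccc1NC(=S)N/N=C/c1ccc2ccccc2n1`, is not yet measured; it differs from compound 2 by 2-methylphenyl in place of 4-methylphenyl on an amide-type nitrogen. Among the measured compounds shown here, the only measured step, from compound 1 to compound 2, exchanges benzyl for 4-methylphenyl on the same nitrogen and stays within the scatter; no measured pair bears on exchanging 4-methylphenyl for 2-methylphenyl. With only this to go on, the step from compound 2 to compound 3 is expected to be a 1.1-fold lower number from compound 2 to compound 3 (0.03 log units; within the scatter), that is none beyond the scatter. Compound 3 is therefore estimated at 80000 nM in this assay, within a range from 35000 nM to 180000 nM.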

Compound 3, half-maximal inhibitory concentration: > 100000 nM
Compound 3 gave a limit, no number (the forecaster's own chance of this, stated with the estimate: 10%); at least 1.2-fold (0.09 log units) between middle value and limit.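

For compound 3, this assay returned a limit and not a number, > 100000 nM. Exchanging 4-methylphenyl for 2-methylphenyl on the amide-type nitrogen gives an at least 1.1-fold higher number from compound 2 to compound 3 (0.06 log units; that floor lies within the scatter), and exchanging benzyl for 2-methylphenyl on that nitrogen gives an at least 1.5-fold higher number from compound 1 to compound 3 (0.20 log units; that floor lies within the scatter), so this position has now been tested with a second methylphenyl group, yet neither exchange is shown to have moved the value beyond the scatter. The true size of both steps stays unknown because of the limit: the limit of > 100000 nM in this assay, at which 1 of the 3 values shown sits.

On these data alone, whether any group on this nitrogen can bring the number clearly lower remains open, since all three compounds carry only benzyl or methylphenyl groups there. As far as these compounds go, it is also open whether an amine, a carboxylic acid or a longer chain at this place would produce a step beyond the scatter.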